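This account rests on a few compounds, and the source may have more. Where it says the series, first, only, none or still open, it means among the compounds named here.

Measured compounds:
Compound 1, `CCOC(=O)C1=C(Nc2ccccc2)S/C(=C\c2ccc(C(=O)O)cc2)C1=O`: in a functional assay on A549 cells (Homo sapiens) for inhibition, read by MTT assay, with a stated time of 72 h, tested at 10 uM (on this read-out higher numbers stand for more inhibition at the one concentration tested (going by the name of the read-out) and lower numbers for less inhibition), compound 1 gives 11.6%.
Compound 2, `CCOC(=O)C1=C(Nc2ccccc2)S/C(=C\c2cc[nH]c2)C1=O`: in this assay compound 2 gives < 10%, which is a limit of the assay and not a number.

Compound 2 thus stands at the limit of < 10% in this assay, at which 1 of the 2 values shown sits, so only a ceiling for its inhibition is known. For the measured compounds named here, the one measured step, a number at least 1.6 percentage points lower from compound 1 to compound 2 (that floor lies within the scatter), swaps the ring at the same position that changes again here, and its size stays within the scatter of repeated measurements.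

Compound 3, `CCOC(=O)C1=C(Nc2ccccc2)S/C(=C\c2cc3ccncc3[nH]2)C1=O`, is not yet measured. It differs from compound 2 in this way: a group of 9 heavy atoms (7 carbon, 2 nitrogen; one five-membered aromatic ring with 1 hetero atom, one six-membered aromatic ring with 1 hetero atom) in place of a group of 5 heavy atoms (4 carbon, 1 nitrogen; one five-membered aromatic ring with 1 hetero atom), on a double-bonded chain carbon bound to a double-bonded ring carbon.

The measured step from compound 1 to compound 2 is the only one that bears on this change, and it shows that exchanging the ring at this position gave no shift beyond the scatter. The same kind of outcome is expected in this assay: a step of a number no lower from compound 2 to compound 3 (the limit leaves the size open), no larger than the scatter. Compound 3 is therefore estimated to give 10% in this assay, expected to fall between 0% and 25%.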

Compound 3, a percentage reported as inhibition, at one concentration (the size of the read-out at that concentration, not a potency): 17.1%
Compound 3: middle estimate off by 7.1 percentage points, on the low side, and the stated range covers the measured number.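

In this assay, replacing 1H-pyrrol-3-yl with the larger group that holds a five-membered and a six-membered aromatic ring, on a double-bonded chain carbon bound to a double-bonded ring carbon, gives a number at least 7.1 percentage points higher from compound 2 to compound 3 (that floor lies within the scatter). The value of compound 2 is a limit of the assay and not a number, so the true size of this step stays unknown: the limit of < 10% in this assay, at which 1 of the 3 values shown sits.

Exchanging 4-carboxyphenyl for the same larger group gives a number 5.5 percentage points higher from compound 1 to compound 3 (within the scatter), which means that three quite different ring groups have now stood at this position, and no step among them is shown to exceed the scatter, though the limit on compound 2 leaves that one step open.

From the compounds shown here alone, whether a group of another kind at this position, such as an amine or a longer chain, would move the inhibition beyond the scatter remains open. The shared core is also the same in all of these compounds, so it is equally open what an amide in place of the ethyl ester would do, or how any of them would behave at a concentration other than the one tested.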